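The source may hold more compounds than are shown below. What is called first, only, known or untested is meant among the compounds shown, and "the series" means these compounds.

Going by the values given here, compound 2 `Cc1ccc(Nc2ncnc3c2nnn3Cc2ccccc2Cl)cc1` is the lower of the two numbers so far in an assay on cell membranes for binding affinity to adenosine receptor A1 (Bos taurus), read by radioligand binding; on this read-out lower numbers stand for stronger inhibition and higher numbers for weaker inhibition: compound 2 gives 119 nM. Compound 1 `c1ccc(Cn2nnc3c(NCC4CCCCC4)ncnc32)cc1` sits much weaker in the same assay, and compound 1 gives 2790 nM, a gap that lies well beyond the scatter of this assay; compound 1 also differs from compound 2 in more than one place, so the two values are simply shown side by side. Compound 3 `O=[N+]([O-])c1cccc(Nc2ncnc3c2nnn3Cc2ccccc2Cl)c1` is not yet measured. The change from compound 2 to compound 3 is 3-nitrophenyl in place of 4-methylphenyl on a nitrogen on an aromatic ring. Among the compounds with values here, no step between two measured compounds matches this change. The expected step is a 1.8-fold higher number from compound 2 to compound 3 (0.27 log units; within the scatter), a modest weakening that may not exceed the scatter. Compound 3 is therefore estimated at 220 nM in this assay, with a range from 55 nM to 900 nM.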

Compound 3, inhibition constant: 3300 nM
Beside the measured number, compound 3's estimate is 15-fold (1.18 log units) below it; measured number above the stated range.
By their numbers in this assay, from the lowest: compound 2; then compounds 1 and 3 (each within the scatter of the next).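

With the rest of compound 2 kept, the position on the nitrogen on an aromatic ring proves sensitive in this assay: replacing 4-methylphenyl with 3-nitrophenyl gives a 28-fold higher number from compound 2 to compound 3 (1.44 log units; beyond the scatter). The first two compounds differ in more than one place, so they could not show how much this position alone can shift the number. This single change is therefore the first direct sign that the group held there matters, and it moves the number upward, but nothing at hand accounts for the size of the step. The step changes both the substituent and its place on the phenyl ring, and the compounds shown do not separate these two changes. From the compounds shown here alone, how an amine, a methoxy group or a carboxylic acid on that ring would compare also remains open.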